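This account rests on a few compounds, and the source may have more. Where it says the series, first, only, none or still open, it means among the compounds named here.

Measured so far in a functional assay on AN3-CA cells (Homo sapiens) for antiproliferative activity, read by MTT assay, with a stated time of 72 h; on this read-out higher numbers stand for weaker inhibition and lower numbers for stronger inhibition:
Compound 1 `O=C(Nc1ccc(Cl)c(-c2nnc3c(Cl)cccn23)c1)c1ccccn1`; compound 1 gives > 100000 nM, which is a limit of the assay.
Compound 2 `O=C(Nc1ccc(Cl)c(-c2nnc3c(Cl)cccn23)c1)c1cccnc1`; compound 2 gives > 100000 nM, also a limit of the assay.
Compound 3 `O=C(Nc1ccc(Cl)c(-c2nnc3c(Cl)cccn23)c1)c1cccc(Cl)c1`; compound 3 gives 68400 nM.

Among the compounds with values here, compound 3 is the only member of the series with a number in this assay; the other two sit at the limit of > 100000 nM in this assay, at which 2 of the 3 values shown sit. The shared core of compound 3 is held constant throughout, and the three measured compounds differ only in the aryl group on the carbonyl carbon.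

Compound 4 `CS(=O)(=O)c1ccc(C(=O)Nc2ccc(Cl)c(-c3nnc4c(Cl)cccn34)c2)cc1` is the next variation: 4-(methylsulfonyl)phenyl in place of 3-chlorophenyl on a carbonyl carbon. The measured steps that bear on it are an at least 1.4-fold lower number from compound 1 to compound 3 (0.16 log units; that floor lies within the scatter) and an at least 1.4-fold lower number from compound 2 to compound 3 (0.16 log units; that floor lies within the scatter), both read against a limit, so their true size is not known. Replacing the 3-chlorophenyl of compound 3 with an aryl group carrying two hydrogen-bond acceptors moves back toward the kind of substituent that gave only limits in compound 1 and compound 2. The step from compound 3 to compound 4 in this assay is therefore expected to raise the number, a 1.3-fold higher number from compound 3 to compound 4 (0.12 log units; within the scatter), with a real chance that only a limit is recorded.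

Compound 4 is estimated at 90000 nM in this assay, within 30000 nM to 300000 nM.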

Compound 4, half-maximal inhibitory concentration: > 100000 nM
Compound 4: a limit, no number; the forecaster's own chance of this, stated with the estimate: 60%; at least 1.1-fold (0.04 log units) between middle value and limit.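

In this assay the 4-(methylsulfonyl)phenyl group on the carbonyl carbon gives an at least 1.4-fold higher number from compound 3 to compound 4 (0.16 log units; that floor lies within the scatter); this is only a floor, since compound 4 gives a limit of the assay and not a number. Within the data shown here, until now the limit had been seen only with the pyridin-2-yl of compound 1 and the pyridin-3-yl of compound 2, whereas compound 4 reaches it with a six-membered aromatic ring of carbon only, the same ring type as in compound 3, so that ring type alone does not secure a number at this position. Among these compounds, the steps from compound 1 and from compound 2 to compound 4 cannot be read, as both ends of each are limits, and compound 3 remains the only member with a number: the limit of > 100000 nM in this assay, at which 3 of the 4 values shown sit.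

Going by these compounds, how far compound 4 truly lies from compound 3 stays open, as does whether the chlorine of compound 3 is what separates it from the other three. A phenyl ring carrying a trifluoromethyl group, an amine or a carboxylic acid on this carbonyl carbon would say more about which substituents give a number in this assay.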